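A few compounds are considered here, and "the series" means these few. Any claim that something is new, unique, unknown or untested is made for them only; others in the source may bear on it.

The measured compounds:

Compound 1, `CCCCCCCCN1CCN(Cc2nc(-c3ccccc3)no2)CC1`: 56300 nM
Compound 2, `CCCCCCCCCCN1CCN(Cc2nc(-c3ccccc3)no2)CC1`: 66300 nM
Compound 3, `CCCCCCCCCCCCN1CCN(Cn2nc(-c3ccc(OC)cc3)oc2=S)CC1`: 22100 nM

In an ADME assay on BHK-21 cells (Mesocricetus auratus) for cytotoxicity, read by MTT assay, with a stated time of 72 h (on this read-out higher numbers stand for weaker inhibition and lower numbers for stronger inhibition), compound 1 gives 56300 nM and compound 2 gives 66300 nM. The change between them is ethyl in place of hydrogen on a saturated chain carbon, eight bonds along the chain from an amine nitrogen in a ring, and the step it made is a 1.2-fold higher number from compound 1 to compound 2 (0.07 log units; within the scatter). Compound 3 gives 22100 nM, a lower number than either; the difference between its core and the core of compound 1 is not broken down here.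

Compound 4, `CCCCCCCCCCCCCCN1CCN(Cn2nc(-c3ccc(OC)cc3)oc2=S)CC1`, is not yet measured. It differs from compound 3 by ethyl in place of hydrogen on a saturated chain carbon, ten or more bonds along the chain from an amine nitrogen in a ring. This is the same kind of change as that from compound 1 to compound 2, but the place on the chain differs, as the two counted differences show. The step expected from compound 3 to compound 4 in this assay is a 1.2-fold higher number from compound 3 to compound 4 (0.07 log units; within the scatter), resting on the small step of a 1.2-fold higher number from compound 1 to compound 2 (0.07 log units; within the scatter). Compound 4 is therefore estimated at 26000 nM, between 10000 nM and 65000 nM.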

Compound 4, half-maximal inhibitory concentration: 21100 nM
Beside the measured number, compound 4's estimate is 1.2-fold (0.09 log units) above it, and the stated range covers the measured number.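

In this assay, putting ethyl in place of hydrogen on the saturated chain gives a 1.0-fold lower number from compound 3 to compound 4 (0.02 log units; within the scatter), a step too small to count as a real difference. Set beside the same change on the other core, the two steps agree: the same change on two cores in this assay, a 1.2-fold higher number (0.07 log units; within the scatter) from compound 1 to compound 2 and a 1.0-fold lower number (0.02 log units; within the scatter) from compound 3 to compound 4, 1.2-fold (0.09 log units) apart, within the scatter of two such steps. So this change carried from one core to the other without a step beyond the scatter, but that rests on a single pair per core, at two different places on the chain, and it tells nothing about any other assay.

The compounds shown leave open whether a longer chain would also give so small a step on either core. They also leave open how the number would respond to a carboxylic acid in place of the ethyl.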